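This account rests on a few compounds, and the source may have more. Where it says the series, first, only, none or still open, it means among the compounds named here.

Among the measured compounds shown here, in a functional assay on COLO 205 cells (Homo sapiens) for inhibition, read by MTT assay, with a stated time of 24 h (on this read-out lower numbers stand for stronger inhibition and higher numbers for weaker inhibition), compound 2 `C/C=C(\C)C(=O)O[C@@H]1[C@]2(OC(=O)CCCC)C=C3C4=CC(=O)O[C@@H](c5ccoc5)[C@]4(C)CC[C@@H]3[C@@]3(C)[C@H](C[C@]1(C)[C@H]3[C@@H](O)C(=O)OC)O2` gives 4000 nM, the only true number so far. Compound 1 `C/C=C(\C)C(=O)O[C@@H]1[C@]2(OC(=O)CCCC)C=C3C4=CC(=O)O[C@@H](c5ccoc5)[C@]4(C)CC[C@@H]3[C@@]3(C)[C@H](C[C@]1(C)[C@H]3[C@@H](OC(=O)CCCC)C(=O)OC)O2` reports only a limit, > 100000 nM. Compound 3 `C/C=C(\C)C(=O)O[C@@H]1[C@]2(OC(=O)CC)C=C3C4=CC(=O)O[C@@H](c5ccoc5)[C@]4(C)CC[C@@H]3[C@@]3(C)[C@H](C[C@]1(C)[C@H]3[C@@H](O)C(=O)OC)O2` shortens one chain of compound 2, butylcarbonyl to propanoyl: hydrogen in place of ethyl on a saturated chain carbon, two bonds along the chain from a carbonyl carbon. For the measured compounds named here, the one measured step, an at least 25-fold lower number from compound 1 to compound 2 (1.39 log units; beyond the scatter), removed a different butylcarbonyl entirely, so it bears only loosely on this trim, though it points toward lower numbers. A much smaller change is involved here, so a 1.3-fold lower number from compound 2 to compound 3 (0.12 log units; within the scatter) is expected to be small, leaning slightly lower. For compound 3 the estimated value is 3000 nM, with an expected range from 1200 nM to 8000 nM.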

Compound 3, half-maximal inhibitory concentration: > 100000 nM
Compound 3: only a limit was reported (the forecaster's own chance of this, stated with the estimate: 5%); middle value at least 33-fold (1.52 log units) away from the limit.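

Shortening butylcarbonyl to propanoyl is no minor trim: in this assay it gives an at least 25-fold higher number from compound 2 to compound 3 (1.39 log units; beyond the scatter). Among the compounds shown here, the earlier step concerned a different butylcarbonyl, so this is the first sign that the length of this chain also matters, with the ethyl that leaves needed to keep a measurable number. The value for compound 3 is only a limit, so the true size of the step stays unknown: the limit of > 100000 nM in this assay, at which 2 of the 3 values shown sit.

Open, on these data alone, is whether a longer chain, such as hexanoyl, would lower the number further or raise it. An amine at the end of this chain is equally untested here.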